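The source may hold more compounds than are shown below. What is called first, only, known or untested is meant among the compounds shown, and "the series" means these compounds.

In an ADME assay on S9 fraction from liver (Mus musculus) for metabolic stability, read by LC-MS, using NADPH, with a stated time of 45 min, tested at 3 uM, in the presence of a further agent that is not named here (on this read-out lower numbers stand for lower hepatic extraction and higher numbers for higher hepatic extraction), compound 2 `COc1cc(F)ccc1-c1cc2c(cn1)ncn2-c1ccc(OC(F)F)cc1` gives 0.21. Of the two numbers recorded, compound 2 stands lowest; compound 1 `COc1ccc(-n2cnc3cnc(-c4ccc(F)cc4C)cc32)cc1` gives 1, a gap well beyond the usual scatter. Compound 3 `Fc1ccc(-c2cc3c(cn2)ncn3-c2ccc(OC(F)F)cc2)c(C(F)(F)F)c1` was also tested, but in this assay compound 3 gives "not determined" (no result reported), so no result was reported for it. Compound 4 `Cc1cc(F)c(F)cc1-c1cc2c(cn1)ncn2-c1ccc(OC(F)F)cc1` has not yet been measured. It differs from compound 2 in one place: 4,5-difluoro-2-methylphenyl in place of 4-fluoro-2-methoxyphenyl on an aromatic carbon. The change sits on an aromatic carbon of a six-membered aromatic ring with one nitrogen, part of a fused system of two rings, next to the ring nitrogen. Among the compounds with values here, with no comparable measured pair to lean on, the step is expected to stay within the scatter, as a number 0.030 lower from compound 2 to compound 4 (within the scatter) shows. Compound 4 is therefore estimated at 0.18, within the range 0.07 to 0.4.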

Compound 4, hepatic extraction ratio in the Mus musculus assay: 0.15
Compound 4: middle estimate off by 0.030, on the high side, within the range that was stated.
By their numbers in the Mus musculus assay, from the lowest: compounds 4 and 2 (each within the scatter of the next); then compound 1.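

At the aromatic carbon next to the ring nitrogen, replacing 4-fluoro-2-methoxyphenyl with 4,5-difluoro-2-methylphenyl leaves the picture in the Mus musculus assay unchanged, with a number 0.060 lower from compound 2 to compound 4 (within the scatter). In a physicochemical assay for solubility (a higher number here means a more soluble compound, a lower number a less soluble compound), compound 2 gives 3000 nM and compound 4 gives 15000 nM. So this one change separates the two compounds on solubility but not on hepatic extraction: the measured solubility of compound 2, 3000 nM, and of compound 4, 15000 nM, a 5.0-fold higher number (0.70 log units; beyond the scatter)

From the compounds shown here alone, whether the methyl or the second fluorine carries the solubility step stays open. Also open, going by these compounds, is how an amine, a carboxylic acid or a longer chain would behave on this same carbon.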